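From 4-cyanophenyl to 3,4-dichlorophenyl at the assay limit

The source may hold more compounds than are shown below. What is called first, only, known or untested is meant among the compounds shown, and "the series" means these compounds.

In a functional assay on SW-620 cells (Homo sapiens) (on this read-out higher numbers stand for weaker inhibition of growth and lower numbers for stronger inhibition of growth), compound 1 `O=S(=O)(/C=C/c1ccccc1)Cc1ccc(Nc2ncnc3ccccc23)cc1` gives > 100000 nM, which is a limit. Compound 2 `O=S(=O)(/C=C/c1ccc(F)cc1)Cc1ccc(Nc2ncnc3ccccc23)cc1` reads 100000 nM. Compound 3 `N#Cc1ccc(/C=C/S(=O)(=O)Cc2ccc(Nc3ncnc4ccccc34)cc2)cc1` gives > 100000 nM, again a limit. Compound 3 thus stands at the limit of > 100000 nM in this assay, at which 2 of the 3 values shown sit. Compound 4 `O=S(=O)(/C=C/c1ccc(Cl)c(Cl)c1)Cc1ccc(Nc2ncnc3ccccc23)cc1` carries 3,4-dichlorophenyl in place of 4-cyanophenyl on a double-bonded chain carbon bound to a double-bonded chain carbon. The steps of a number no higher from compound 1 to compound 2 (the limit leaves the size open), a step that the two limits leave unreadable from compound 1 to compound 3 and a number no lower from compound 2 to compound 3 (the limit leaves the size open) bear on this change, and limits leave the size of each open. None shows a gain of readable size, so no step beyond the scatter is expected in this assay. The expected step is an at least 1.2-fold lower number from compound 3 to compound 4 (0.09 log units; that floor lies within the scatter). For compound 4 the estimated value is 80000 nM, with an expected range of 25000 nM to 100000 nM.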

Compound 4, concentration for 50% growth inhibition: 41000 nM
Compound 4: middle estimate off by 2.0-fold (0.29 log units), on the high side, within the range that was stated.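

In this assay, among the compounds shown here, 3,4-dichlorophenyl on a double-bonded chain carbon gives the first step at this position that clears the scatter: a 2.4-fold lower number from compound 2 to compound 4 (0.39 log units; beyond the scatter). Measured against the two compounds held at a limit, the change reads as an at least 2.4-fold lower number from compound 3 to compound 4 (0.38 log units; beyond the scatter) and as an at least 2.4-fold lower number from compound 1 to compound 4 (0.38 log units; beyond the scatter), and both sizes are floors. Compound 1 and compound 3 remain limits: the limit of > 100000 nM in this assay, at which 2 of the 4 values shown sit.

From the compounds shown here alone, what 4-chlorophenyl or 3-chlorophenyl alone would give stays open. So does the outcome of a methoxy group or an amine on that ring.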